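The source may report more compounds than this note shows. Statements on the series, on what has been measured and on what is new or still open speak of the compounds shown alone.

Measured in a functional assay on cells (Panel colon (Carcinoma cell lines), Homo sapiens) for inhibition, read by sulforhodamine B assay, with a stated time of 48 h; a lower number here means a stronger inhibitor of growth, a higher number a weaker inhibitor of growth:

- compound 1 `CN1CCN(CCCOc2cccc3nc(Nc4ccc(Cl)c(F)c4)ccc23)CC1`: 1620 nM
- compound 2 `CC(C)c1ccc(Nc2ccc3c(OCCCN4CCN(C)CC4)cccc3n2)cc1`: 4850 nM
- compound 3 `CN1CCN(CCCOc2cccc3nc(Nc4ccc(F)c(F)c4)ccc23)CC1`: 2110 nM

Compound 3 gives 2110 nM, which cannot be told apart from the value of compound 1: the data show a 1.3-fold higher number from compound 1 to compound 3 (0.11 log units; within the scatter). Compound 2 lies further off, with a 2.3-fold lower number from compound 2 to compound 3 (0.36 log units; beyond the scatter).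

Compound 4 `CN1CCN(CCCOc2cccc3nc(Nc4cccc(Cl)c4)ccc23)CC1` has 3-chlorophenyl in place of 3,4-difluorophenyl on a nitrogen on an aromatic ring.

Going by the values given here, two measured steps bear on this change. Exchanging chloro for fluoro on that ring made little difference, as a 1.3-fold higher number from compound 1 to compound 3 (0.11 log units; within the scatter) shows. The larger step, a 3.0-fold higher number from compound 1 to compound 2 (0.48 log units; beyond the scatter), removed both halogens and brought in 4-isopropylphenyl. Compound 4 keeps a halogen on the ring, so it resembles compound 3 more than compound 2. Among the compounds with values here, no measured compound carries a single halogen there, which leaves some uncertainty.

The estimated step is a 1.0-fold higher number from compound 3 to compound 4 (0.02 log units; within the scatter), and none beyond the scatter is expected. For compound 4 the expected value is 2200 nM, with an estimated range of 1100 nM to 4500 nM.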

Compound 4, concentration for 50% growth inhibition: 1640 nM
Compound 4: the middle estimate sits 1.3-fold (0.13 log units) above what was measured, and the stated range covers the measured number.
By their numbers in this assay, from the lowest: compounds 1, 4 and 3 (each within the scatter of the next); then compound 2.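

A single chlorine on the ring attached to this nitrogen does as well in this assay as either ring with two halogens, so the second halogen brings no measurable change here (for 3-chlorophenyl, a 1.3-fold lower number from compound 3 to compound 4 (0.11 log units; within the scatter) and a 1.0-fold higher number from compound 1 to compound 4 (0.01 log units; within the scatter)). The separation from the 4-isopropylphenyl ring remains clear (a 3.0-fold lower number from compound 2 to compound 4 (0.47 log units; beyond the scatter)), and all three halogen-bearing rings now stand apart from it, with no exception among these four compounds. No evidence is available to explain these differences.

The compounds shown do not include plain phenyl or 4-chlorophenyl on this nitrogen, so it remains open whether any halogen is needed and whether the place of the chlorine matters. On these data alone, how a small non-halogen group such as methoxy or a nitrile would compare also remains open.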